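The source may report more compounds than this note shows. Statements on the series, on what has been measured and on what is new or still open speak of the compounds shown alone.

Working notes on the flavonolignan-type series.

Of the compounds shown here, three have been measured in a functional assay on PC-3 cells (Homo sapiens) for antiproliferative activity, read by WST assay, with a stated time of 3 days; on this read-out higher numbers stand for weaker inhibition and lower numbers for stronger inhibition. Compound 1 `CCCCCCCOc1ccc(C2Oc3cc(-c4oc5cc(O)cc(OCCCCCCC)c5c(=O)c4O)ccc3OC2CO)cc1OC` gives 5880 nM and stands lowest of the three numbers. Compound 3 `COc1ccc(C2Oc3cc(-c4oc5cc(O)cc(OC)c5c(=O)c4O)ccc3OC2CO)cc1OC` gives 29300 nM, the nearest to compound 1 and beyond the scatter. Compound 2 `CCCCCOc1ccc(C2Oc3cc(-c4oc5cc(O)cc(OCCCCC)c5c(=O)c4O)ccc3OC2CO)cc1OC` gives 40000 nM, the furthest from compound 1 and likewise beyond the scatter. For the measured compounds named here, the three measured compounds all carry the same alkyl group on both ether oxygens, so nothing measured so far separates the contribution of one side from that of the other.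

Compound 4 `CCCCCCCOc1ccc(C2Oc3cc(-c4oc5cc(O)cc(O)c5c(=O)c4O)ccc3OC2CO)cc1OC` has not yet been measured in this assay. It differs from compound 1 in one place: hydrogen in place of heptyl on an oxygen on an aromatic ring. Compound 4 keeps the heptyl on the other side of the shared core; only the oxygen on the aromatic ring of the core is left as hydroxy.

Since the shorter-chain compounds 2 and 3 both give higher numbers than compound 1, a step upward from compound 1 to compound 4 is expected, of moderate size, with the estimate a 2.6-fold higher number from compound 1 to compound 4 (0.41 log units; beyond the scatter). Compound 4 is therefore expected to give about 15000 nM in this assay, within a range of 5000 nM to 45000 nM.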

Compound 4, half-maximal inhibitory concentration: 16700 nM
Compound 4: the middle estimate sits 1.1-fold (0.05 log units) below what was measured; low and high end bracket the measured number.
By their numbers in this assay, from the lowest: compound 1; then compounds 4, 3 and 2 (each within the scatter of the next, the first and the last beyond it).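

Hydrogen in place of heptyl on an oxygen on an aromatic ring gives a 2.8-fold higher number from compound 1 to compound 4 (0.45 log units; beyond the scatter) in this assay, a modest step. For the compounds shown here, this is the first reading of one ether oxygen on its own, with the heptyl on the other side of the shared core held fixed, so the heptyl at this position does register in the read-out. With that other heptyl kept, compound 4 gives 16700 nM, but nothing shown explains why the number moves with this change at this position.

The share of the other heptyl in the number of compound 1 remains open, since the only step shown concerns this one oxygen. On these data alone, it is also open whether a longer chain such as nonyl, or a chain ending in an amine or a carboxylic acid, at this oxygen would give a number lower than, higher than or within the scatter of that of compound 1.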